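Swapping the halogenated anilide ring for a nitrile-bearing one

This account rests on a few compounds, and the source may have more. Where it says the series, first, only, none or still open, it means among the compounds named here.

Measured compounds:
compound 1, `O=C(Nc1ccc(Cl)cc1)C(=O)N1CCC(c2ccnc3ccc(F)cc23)CC1`: 9 mL.min-1.g-1
compound 2, `O=C(Nc1ccc(Cl)cc1F)C(=O)N1CCC(c2ccnc3ccc(F)cc23)CC1`: 10 mL.min-1.g-1

In an ADME assay on microsomes from liver (Homo sapiens) for metabolic stability (a lower number here means slower removal, a higher number faster removal of the compound), compound 1 gives 9 mL.min-1.g-1 and compound 2 gives 10 mL.min-1.g-1. Compound 2 stands level with compound 1, as the step of a 1.1-fold higher number from compound 1 to compound 2 (0.05 log units; within the scatter) shows. Compound 3, `N#Cc1ccc(NC(=O)C(=O)N2CCC(c3ccnc4ccc(F)cc34)CC2)cc1`, carries the change (4-cyanophenyl in place of 4-chloro-2-fluorophenyl on an amide-type nitrogen). Among the compounds with values here, the single measured step exchanges a hydrogen for a fluorine and says nothing about replacing one ring for another bearing a nitrile. Within the data shown here, with no comparable step available, no shift beyond the scatter is expected, and the step of a 1.3-fold lower number from compound 2 to compound 3 (0.10 log units; within the scatter) is estimated accordingly. Compound 3 is therefore expected at 8 mL.min-1.g-1, within the range 4 mL.min-1.g-1 to 16 mL.min-1.g-1.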

Compound 3, intrinsic clearance in microsomes: 11 mL.min-1.g-1
The estimate for compound 3 lay 1.4-fold (0.14 log units) below the measured number, and the stated range covers the measured number.
By their numbers in this assay, from the lowest: compounds 1, 2 and 3 (each within the scatter of the next).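

At this amide-type nitrogen, 4-cyanophenyl in place of 4-chloro-2-fluorophenyl gives a 1.1-fold higher number from compound 2 to compound 3 (0.04 log units; within the scatter) in this assay, and cyano in place of chloro on an aromatic carbon gives a 1.2-fold higher number from compound 1 to compound 3 (0.09 log units; within the scatter) on the same read-out. The earlier compounds shown here carried only halogens on this ring, and now a nitrile also leaves the number within the scatter. Nothing available gives a reason for this result. Still open, from the compounds shown here alone, is whether a ring bearing an amine or a carboxylic acid, or a saturated cyclohexyl ring, would stay as close.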